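Growing the Alkoxy Group on a Weak Binder

This account rests on a few compounds, and the source may have more. Where it says the series, first, only, none or still open, it means among the compounds named here.

Of the compounds shown here, three have been tested in an assay on HEK293 cells for displacement of a labelled ligand from Translocator protein (Homo sapiens), read by scintillation counting, with a stated time of 90 min; on this read-out lower numbers stand for stronger inhibition and higher numbers for weaker inhibition. Compound 1, `CCN(CC)C(=O)Cn1c(-c2ccc(OC)cc2)cc2c(C)cc(C)cc21`, gives 652 nM. Compound 2, `CN(Cc1ccccc1)C(=O)c1nc2ccccc2n1Cc1ccc(Cl)cc1`, gives only a limit, > 10000 nM. Compound 3, `COc1ccc(CN(C(C)=O)c2cc(C)cc(C)c2)cc1`, gives 2790 nM, the higher of the two actual numbers; its nearest neighbour, compound 1, sits at a lower number, and that gap lies beyond the usual scatter. Compound 4, `CC(=O)N(Cc1ccc(OC(C)C)cc1)c1cc(C)cc(C)c1`, differs from compound 3 in one place: isopropyl in place of methyl on an oxygen on an aromatic ring, so the methoxy becomes an isopropoxy. Within the data shown here, no measured pair shows this change, so any expectation rests on compound 3 alone. A modest step toward stronger binding, or none beyond the scatter, is expected, a 1.9-fold lower number from compound 3 to compound 4 (0.27 log units; within the scatter). Compound 4 is estimated at 1500 nM, in the range 500 nM to 5000 nM.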

Compound 4, inhibition constant: 3150 nM
Estimate against measurement, compound 4: 2.1-fold (0.32 log units) below; the measured number falls inside the stated range.
By their numbers in this assay, from the lowest: compound 1; then compounds 3 and 4 (each within the scatter of the next). At a limit, above all of these: compound 2.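

Among these compounds, the pair of compound 3 and compound 4 is the first here to differ in only one place. Isopropyl in place of methyl on an oxygen on an aromatic ring gives a 1.1-fold higher number from compound 3 to compound 4 (0.05 log units; within the scatter) in this assay, so this position accepts 3 heavy atoms where there was 1, with no change that can be told from the scatter. Nothing measured here accounts for this result.

On these data alone, what a longer chain or a carboxylic acid on this oxygen would give remains open. So does whether the same change would read alike on the core of compound 1, which also carries a methoxy.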